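The source may hold more compounds than are shown below. What is called first, only, known or untested is meant among the compounds shown, and "the series" means these compounds.

Measured so far in a functional assay on HepG2 cells (Homo sapiens) for antiproliferative activity, read by MTT assay, with a stated time of 72 h; a higher number here means a weaker inhibitor, a lower number a stronger inhibitor:
- Compound 1 `Cc1noc(C)c1-c1nn(Cc2ccc(C(=O)NC3CC3)cc2)c(=O)c2ccccc12`: > 100000 nM
- Compound 2 `O=C(Nc1ccccc1Cl)c1ccc(Nc2nn(Cc3ccc(C(=O)NC4CCCCC4)cc3)c(=O)c3ccccc23)cc1`: 82400 nM

Compound 1 stands at a limit of this assay, not at an exact number: > 100000 nM. Compound 2 does give a number, 82400 nM, which is still a high value on a scale where higher means weaker. The two measured compounds differ in more than one place, so no single measured change is available as a guide.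

The next compound, compound 3 `Cc1noc(C)c1-c1nn(Cc2ccc(C(=O)NC3CCCC3)cc2)c(=O)c2ccccc12`, keeps the rest of compound 1 and makes one change: cyclopentyl in place of cyclopropyl on an amide-type nitrogen. For the measured compounds named here, with no measured step to draw on, the starting point is the weak reading of compound 1, > 100000 nM, and no large gain is expected from this one swap. The expected change, a number no higher from compound 1 to compound 3 (the limit leaves the size open), is none beyond the usual scatter, in either direction, and another limit would be no surprise. The estimate for compound 3 is 100000 nM, with an expected range from 40000 nM to 200000 nM.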

Compound 3, half-maximal inhibitory concentration: > 100000 nM
Compound 3: a limit, no number; the forecaster's own chance of this, stated with the estimate: 65%; the middle value sits exactly at the limit.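

In this assay compound 3 gives > 100000 nM which is a limit and not a number. For the compounds shown here, compound 1 also stands at a limit, so no step from compound 1 to compound 3 can be read. The compounds shown leave open whether cyclopentyl and cyclopropyl on an amide-type nitrogen differ at all in this assay since both readings stop at the same point: the limit of > 100000 nM in this assay, at which 2 of the 3 values shown sit.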